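The source may hold more compounds than are shown below. What is called first, only, known or untested is meant among the compounds shown, and "the series" means these compounds.

The shared core appears first in compound 1 `CNC(=O)[C@H]1O[C@@H](n2cnc3c(N)nc(Cl)nc32)[C@H](O)[C@@H]1O`, which in an assay on CHO cells for displacement of a labelled ligand from adenosine receptor A3 (Homo sapiens) (a higher number here means a weaker inhibitor, a lower number a stronger inhibitor), gives 0.398 nM. Compound 2 `CNC(=O)[C@H]1O[C@@H](n2cnc3c(NC4CC4)nc(Cl)nc32)[C@H](O)[C@@H]1O` gives 2.24 nM and compound 3 `CNC(=O)[C@H]1O[C@@H](n2cnc3c(NCc4ccccc4C)nc(Cl)nc32)[C@H](O)[C@@H]1O` gives 2.19 nM, so the two of them lie within the scatter of each other; the measured steps are a 5.6-fold higher number from compound 1 to compound 2 (0.75 log units; beyond the scatter) and a 5.5-fold higher number from compound 1 to compound 3 (0.74 log units; beyond the scatter), while a 1.0-fold lower number from compound 2 to compound 3 (0.01 log units; within the scatter). Compound 4 `Cc1ccccc1CNc1nc(Cl)nc2c1ncn2[C@@H]1O[C@H](C(=O)NCC2CC2)[C@@H](O)[C@H]1O` differs from compound 3 by cyclopropyl in place of hydrogen on a saturated chain carbon bound to an amide-type nitrogen. No measured step touches that position; every step shown is at the nitrogen on the aromatic ring, so nothing here speaks to the amide chain. Compound 4 is therefore expected to show a 1.1-fold higher number from compound 3 to compound 4 (0.06 log units; within the scatter), staying near compound 3. The estimated value for compound 4 is 2.5 nM, with a range from 0.8 nM to 8 nM.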

Compound 4, inhibition constant: 29.5 nM
Compound 4: the middle estimate sits 12-fold (1.07 log units) below what was measured; the measured number lies above the stated range.
By their numbers in this assay, from the lowest: compound 1; then compounds 3 and 2 (each within the scatter of the next); then compound 4.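

Going by these compounds alone, the amide chain, which no earlier step touched, proves to be a sensitive position: in this assay cyclopropyl in place of hydrogen on a saturated chain carbon bound to an amide-type nitrogen gives a 13-fold higher number from compound 3 to compound 4 (1.13 log units; beyond the scatter), which makes compound 4 a weaker inhibitor. This step is larger than either step at the nitrogen on the aromatic ring. Nothing at hand explains this loss. On these data alone, it remains open how ethyl or a longer chain at this place would read, and whether the same change would cost as much on compound 1 or compound 2.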